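Thiophene for pyridine at the end of a three-carbon chain

The source may hold more compounds than are shown below. What is called first, only, known or untested is meant among the compounds shown, and "the series" means these compounds.

Three compounds share one core and differ only in the aromatic group that sits on a saturated chain carbon, three bonds along the chain from an oxygen. In a functional assay on 1321-N1 cells for agonist activity at P2Y purinoceptor 2 (Homo sapiens), read by scintillation counting and inositol phosphate accumulation (on this read-out lower numbers stand for an effect already at smaller amounts and higher numbers for an effect only at larger amounts of compound), compound 1 `O=c1[nH]/c(=N\OCCCc2ccc(I)cc2)ccn1[C@@H]1O[C@H](COP(=O)(O)OP(=O)(O)OP(=O)(O)O)[C@@H](O)[C@H]1O` gives 187 nM, compound 2 `O=c1[nH]/c(=N\OCCCc2cccc([N+](=O)[O-])c2)ccn1[C@@H]1O[C@H](COP(=O)(O)OP(=O)(O)OP(=O)(O)O)[C@@H](O)[C@H]1O` gives 457 nM, and compound 3 `O=c1[nH]/c(=N\OCCCc2ccncc2)ccn1[C@@H]1O[C@H](COP(=O)(O)OP(=O)(O)OP(=O)(O)O)[C@@H](O)[C@H]1O` gives 285 nM. Compound 3 thus holds the second highest of the three numbers, with compound 1 nearest and compound 2 furthest, and both of those gaps fall within the scatter. The swaps seen so far were small: a 2.4-fold higher number from compound 1 to compound 2 (0.39 log units; beyond the scatter), a 1.5-fold higher number from compound 1 to compound 3 (0.18 log units; within the scatter), and a 1.6-fold lower number from compound 2 to compound 3 (0.21 log units; within the scatter).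

Compound 4 `O=c1[nH]/c(=N\OCCCc2ccsc2)ccn1[C@@H]1O[C@H](COP(=O)(O)OP(=O)(O)OP(=O)(O)O)[C@@H](O)[C@H]1O` takes the step (thiophen-3-yl in place of pyridin-4-yl on a saturated chain carbon, three bonds along the chain from an oxygen). For the measured compounds named here, the two steps that bear on it are those into and out of pyridin-4-yl, and both lay within the scatter; even the one modest step in this set, from compound 1 to compound 2, stayed small. For compound 4 the expectation is therefore no step beyond the scatter in this assay, a change of about a 1.1-fold lower number from compound 3 to compound 4 (0.04 log units; within the scatter). On that basis compound 4 is estimated at 260 nM, with a range from 120 nM to 560 nM.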

Compound 4, half-maximal effective concentration: 103 nM
For compound 4 the middle estimate is 2.5-fold (0.40 log units) above the measured one, outside the stated range (below it).
By their numbers in this assay, from the lowest: compounds 4, 1, 3 and 2 (each within the scatter of the next, the first and the last beyond it).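

In this assay, for the compounds shown here, the aromatic group at this position makes more difference than the earlier compounds showed: thiophen-3-yl in place of pyridin-4-yl gives a 2.8-fold lower number from compound 3 to compound 4 (0.44 log units; beyond the scatter), the only step touching pyridin-4-yl that lies beyond the scatter, and thiophen-3-yl in place of 3-nitrophenyl gives a 4.4-fold lower number from compound 2 to compound 4 (0.65 log units; beyond the scatter), now the largest step in the set. The comparison with the 4-iodophenyl group reads a 1.8-fold lower number from compound 1 to compound 4 (0.26 log units; within the scatter), so a five-membered aromatic ring on this saturated chain carbon cannot be told apart from the six-membered ring of compound 1 and sits clear of the other two groups. Nothing available here accounts for the gap between thiophen-3-yl and pyridin-4-yl.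

From the compounds shown here alone, whether this result belongs to thiophen-3-yl alone stays open, and thiophen-2-yl, furan-3-yl or an unsubstituted phenyl on the same chain carbon would speak to that. Going by these compounds, the chain is also open, since all four compounds carry the same length and a 2-(thiophen-3-yl)ethyl or a 4-(thiophen-3-yl)butyl group would show how far the thiophene result depends on it.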